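A few compounds are considered here, and "the series" means these few. Any claim that something is new, unique, unknown or untested is made for them only; others in the source may bear on it.

In an assay for inhibition of MAP kinase-interacting serine/threonine-protein kinase 1 (Homo sapiens), read by luminescence and ADP-Glo, with a stated time of 2 h (on this read-out higher numbers stand for weaker inhibition and lower numbers for stronger inhibition), compound 1 `Nc1n[nH]c2cc(-c3ccc(=O)n(Cc4cccc(Cl)c4)c3)ccc12` gives 11 nM. Compound 2 `O=C(N1CCOCC1)n1cc(-c2ccc3cn[nH]c3c2)ccc1=O` reaches only the limit of this assay, > 2000 nM. Compound 3 `O=c1ccc(-c2ccc3cc[nH]c3c2)cn1Cc1ccccc1` likewise reaches only the limit, > 2000 nM. Compound 2 therefore stands at the weak end of the measured set, at the limit of > 2000 nM in this assay, at which 2 of the 3 values shown sit, together with compound 3. Compound 4 `O=c1ccc(-c2ccc3cn[nH]c3c2)cn1Cc1ccccc1Cl` differs from compound 2 by 2-chlorobenzyl in place of (morpholin-4-yl)carbonyl on an aromatic nitrogen. Going by the values given here, no measured pair of compounds differs in this single place, so the size of this step in this assay is not fixed by the data. Compound 1, which also bears a substituted benzyl on a ring nitrogen, gives 11 nM, so a move toward stronger inhibition is expected. The step from compound 2 to compound 4 is estimated at an at least 13-fold lower number from compound 2 to compound 4 (1.12 log units; beyond the scatter). For compound 4 the expected value is 150 nM, within a range from 20 nM to 1500 nM.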

Compound 4, half-maximal inhibitory concentration: 80 nM
For compound 4 the middle estimate is 1.9-fold (0.27 log units) above the measured one; measured number inside the range.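

Going by these compounds alone, this step is the first to isolate a change on the aromatic nitrogen. In this assay, 2-chlorobenzyl in place of (morpholin-4-yl)carbonyl gives an at least 25-fold lower number from compound 2 to compound 4 (1.39 log units; beyond the scatter), so the group held at this nitrogen strongly affects the read-out, even though both groups contain 8 heavy atoms. The step is only a minimum, as the value for compound 2 is a limit and not a number: the limit of > 2000 nM in this assay, at which 2 of the 4 values shown sit.

As far as these compounds go, the part played by the chlorine remains open, as does the effect of its place on the benzyl ring. A plain benzyl, a 2-phenylethyl chain or a benzyl bearing a carboxylic acid could help settle how far this trend extends on the core of compound 4.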